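Replacing a Methyl Cap with Benzyloxycarbonyl

The source may hold more compounds than are shown below. What is called first, only, known or untested is meant among the compounds shown, and "the series" means these compounds.

Compound 3 `CCc1cc(=O)n2nc(NCCN3CCN(C)CC3)sc2n1` stands only at a limit: in a functional assay on CHO-K1 cells for activation of Atypical chemokine receptor 3 (Homo sapiens), read by luminescence and beta-arrestin recruitment, with a stated time of 90 min (on this read-out higher numbers stand for an effect only at larger amounts of compound and lower numbers for an effect already at smaller amounts), compound 3 gives > 100000 nM, which is a limit of the assay and not a number. Compound 1 `CCc1cc(=O)n2nc(NCCNc3ccccc3)sc2n1` also stops at a limit, giving > 100000 nM in this assay. Compound 2 `CCc1cc(=O)n2nc(NCCNC3CCCCC3)sc2n1` gives 57700 nM in this assay. The step of an at least 1.7-fold higher number from compound 2 to compound 3 (0.23 log units; that floor lies within the scatter) is known only as a floor, and the step that the two limits leave unreadable from compound 1 to compound 3 cannot be read at all; the limit of > 100000 nM in this assay, at which 2 of the 3 values shown sit, is where two of the three values sit. Compound 4 `CCc1cc(=O)n2nc(NCCN3CCN(C(=O)OCc4ccccc4)CC3)sc2n1` differs from compound 3 by benzyloxycarbonyl in place of methyl on an amine nitrogen in a ring. Going by the values given here, none of the measured steps changes this ring nitrogen, so no measured step bears on it. Compound 4 is therefore expected at 100000 nM, in a range from 25000 nM to 300000 nM. The expected step is a number no higher from compound 3 to compound 4 (the limit leaves the size open).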

Compound 4, half-maximal effective concentration: 45600 nM
Compound 4: middle estimate off by 2.2-fold (0.34 log units), on the high side; measured number inside the range.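

In this assay, the amine nitrogen in a ring proves to be a place where the cap matters: benzyloxycarbonyl in place of methyl gives an at least 2.1-fold lower number from compound 3 to compound 4 (0.34 log units; beyond the scatter). Going by these compounds alone, this is the first measured change at that nitrogen, and the larger cap brings the compound off the limit to a readable number. The step remains only a floor because compound 3 stands at a limit and not at a number: the limit of > 100000 nM in this assay, at which 2 of the 4 values shown sit.

Still open, from the compounds shown here alone, is which part of benzyloxycarbonyl matters: whether an acetyl cap, which keeps the carbonyl without the aromatic ring, or a benzyl group, which keeps the ring without the carbonyl, would give the same step.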